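This account rests on a few compounds, and the source may have more. Where it says the series, first, only, none or still open, it means among the compounds named here.

Measured so far:
- compound 1 `Cc1c(Cc2ccc(C(F)(F)F)nc2)c[nH]c1C(=O)NC(C)c1cnn(C)c1`: 20000 mL.min-1.g-1
- compound 2 `Cc1cc(C(C)NC(=O)c2[nH]cc(Cc3ccc(C(F)(F)F)nc3)c2C)no1`: 34000 mL.min-1.g-1

Both numbers come from an ADME assay on microsomes from liver (Homo sapiens) for metabolic stability, read by LC-MS, with a stated time of 4 h, tested at 1 uM; on this read-out higher numbers stand for fast clearance and lower numbers for slow clearance. Only these two compounds have been measured, and compound 2 cannot be told apart from compound 1 within the usual scatter of this measurement.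

Compound 3 `Cc1c(Cc2ccc(C(F)(F)F)nc2)c[nH]c1C(=O)NC(C)c1cn[nH]c1` keeps the shared core and changes only the ring on a saturated chain carbon bound to an amide-type nitrogen and a saturated chain carbon: 1H-pyrazol-4-yl in place of 5-methyl-1,2-oxazol-3-yl on a saturated chain carbon bound to an amide-type nitrogen and a saturated chain carbon. Its 1H-pyrazol-4-yl stands in place of 5-methyl-1,2-oxazol-3-yl.

Within the data shown here, the one measured exchange of rings at this place is a 1.7-fold higher number from compound 1 to compound 2 (0.23 log units; within the scatter), and it replaced 1-methyl-1H-pyrazol-4-yl with 5-methyl-1,2-oxazol-3-yl. Among the measured compounds shown here, no measured compound carries 1H-pyrazol-4-yl itself, so this single step is a thin guide. Still, it points to a modest change rather than a large one, so no step beyond the scatter is expected. The expected change is a 1.9-fold lower number from compound 2 to compound 3 (0.28 log units; within the scatter). Compound 3 is estimated at 18000 mL.min-1.g-1, with an expected range of 8000 mL.min-1.g-1 to 40000 mL.min-1.g-1.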

Compound 3, intrinsic clearance in microsomes in the Homo sapiens assay: 20000 mL.min-1.g-1
Compound 3: middle estimate off by 1.1-fold (0.05 log units), on the low side, within the range that was stated.
By their numbers in the Homo sapiens assay, from the lowest: compounds 1, 3 and 2 (each within the scatter of the next).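

This result adds a second comparison at this position, and it isolates a single feature: in the Homo sapiens assay, hydrogen in place of methyl on an aromatic nitrogen of the ring gives no change at the digits printed from compound 1 to compound 3 (within the scatter). Exchanging 5-methyl-1,2-oxazol-3-yl for 1H-pyrazol-4-yl on the same saturated chain carbon gives a 1.7-fold lower number from compound 2 to compound 3 (0.23 log units; within the scatter), so this read-out does not separate the three rings shown here, and neither the methyl on the ring nitrogen nor the hydrogen that takes its place registers beyond the scatter. In a physicochemical assay for solubility, with a stated time of 1 h, at pH 1.6 (on this read-out lower numbers stand for lower solubility and higher numbers for higher solubility), compound 2 gives 35.1 ug/mL and compound 3 gives 81 ug/mL. The same exchange does separate compound 2 and compound 3 in the physicochemical assay, where the step is modest but beyond the scatter: the measured solubility of compound 2, 35.1 ug/mL, and of compound 3, 81 ug/mL, a 2.3-fold higher number (0.36 log units; beyond the scatter)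

What lies behind that solubility step stays open, as this single exchange loses the ring oxygen and the ring methyl and brings in 1 hydrogen-bond donor all at once, and the compounds shown do not pull these apart. All three groups are five-membered aromatic rings, so the effect of a phenyl ring, an amine or a carboxylic acid at this place on either read-out is also unknown.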